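This account rests on a few compounds, and the source may have more. Where it says the series, first, only, none or still open, it means among the compounds named here.

Compound 1 (`CCOc1ccc2nc(C(=O)Nc3c(F)cc(-c4cccc(F)c4)cc3F)c(C)c(O)c2c1`) gives > 100000 nM in a functional assay on A-375 cells (Homo sapiens) for antiproliferative activity, read by MTT assay, with a stated time of 24 h (on this read-out higher numbers stand for weaker inhibition and lower numbers for stronger inhibition), which is a limit of the assay and not a number. Compound 2 (`Cc1c(C(=O)Nc2c(F)cc(-c3cccc(F)c3)cc2F)nc2ccc(C(F)(F)F)cc2c1O`) gives 12600 nM. Within the data shown here, the only measured step, an at least 7.9-fold lower number from compound 1 to compound 2 (0.89 log units; beyond the scatter), is trifluoromethyl in place of ethoxy, so it does not test the change at hand and offers only a rough guide to size. Compound 3 (`CCOc1ccc2nc(C(=O)Nc3c(F)cc(-c4cccc(F)c4)cc3F)c(C)c(C(=O)O)c2c1`) carries carboxy in place of hydroxy on an aromatic carbon, opposite the ring nitrogen: carboxy in place of hydroxy on an aromatic carbon. A step of similar size towards stronger inhibition in this assay is expected, with wide uncertainty. The estimated step is an at least 6.6-fold lower number from compound 1 to compound 3 (0.82 log units; beyond the scatter). Compound 3 is estimated at 15000 nM, with a range of 2000 nM to 100000 nM.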

Compound 3, half-maximal inhibitory concentration: 14900 nM
Beside the measured number, compound 3's estimate is 1.0-fold (0.00 log units) above it; the range from low to high includes it.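

Carboxy in place of hydroxy on this aromatic carbon, opposite the ring nitrogen, brings the shared core with ethoxy onto a measurable number in this assay, with an at least 6.7-fold lower number from compound 1 to compound 3 (0.82 log units; beyond the scatter). Compound 1 gives > 100000 nM, which is a limit of the assay and not a number. From the compounds shown here alone, the full size of the step therefore stays unknown, since one end of it rests on that limit: the limit of > 100000 nM in this assay, at which 1 of the 3 values shown sits.

Open, going by these compounds, is whether an amine or a methyl ester on this carbon would also give a measurable number in this assay. Also open, on these data alone, is whether carboxy here gives a similar step when trifluoromethyl stands in place of ethoxy.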